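Selenium-benzyl for methylsulfanyl on the shared core

The source may hold more compounds than are shown below. What is called first, only, known or untested is meant among the compounds shown, and "the series" means these compounds.

Measured compounds:
- compound 1, `CS/C(=N\C(=O)c1csc([N+](=O)[O-])c1)NC(=O)c1csc([N+](=O)[O-])c1`: 41500 nM
- compound 2, `O=C(/N=C(/NC(=O)c1ccno1)[Se]Cc1ccccc1)c1ccno1`: 53100 nM
- compound 3, `O=C(/N=C(/NC(=O)c1cccs1)[Se]Cc1ccccc1)c1cccs1`: 49900 nM

In a functional assay on PC-3 cells (Homo sapiens) for cytotoxicity, read by MTT assay, with a stated time of 72 h (a lower number here means a stronger inhibitor of growth, a higher number a weaker inhibitor of growth), compound 1 gives 41500 nM, the lowest of the three numbers, but its separation from compound 3 at 49900 nM and from compound 2 at 53100 nM is within the scatter of repeated measurements, so no order among the three can be read from these values. Among the measured compounds shown here, the three compounds differ from each other in more than one place, and no step between any pair is counted.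

The unmeasured compound 4, `O=C(/N=C(/NC(=O)c1csc([N+](=O)[O-])c1)[Se]Cc1ccccc1)c1csc([N+](=O)[O-])c1`, differs from compound 1 in one place: a group of 8 heavy atoms (7 carbon, 1 selenium; one six-membered aromatic ring of carbon only) in place of a group of 2 heavy atoms (1 carbon, 1 sulfur; no ring), on a carbon with a double bond to nitrogen. Compound 4 thereby carries the acyl groups of compound 1 together with the selenium-bearing group found in compounds 2 and 3.

For the measured compounds named here, no counted step exists for this change. All three measured compounds, across two different acyl groups and two different groups on the carbon with a double bond to nitrogen, fall within the scatter of one another, which gives no ground to expect a step beyond the scatter in either direction for compound 4 in this assay. The step from compound 1 to compound 4 is expected to be a 1.1-fold higher number from compound 1 to compound 4 (0.04 log units; within the scatter). Compound 4 is expected to give 46000 nM, with a range of 20000 nM to 105000 nM.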

Compound 4, concentration for 50% growth inhibition: 35900 nM
The estimate for compound 4 lay 1.3-fold (0.11 log units) above the measured number, within the range that was stated.
By their numbers in this assay, from the lowest: compounds 4, 1, 3 and 2 (each within the scatter of the next).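

In this assay, among the compounds shown here, the change on a carbon with a double bond to nitrogen, from methylsulfanyl to the group of 8 heavy atoms holding selenium and a six-membered aromatic ring of carbon only, gives a 1.2-fold lower number from compound 1 to compound 4 (0.06 log units; within the scatter) as the first counted step at this position. For the compounds shown here, with the acyl groups of compound 1 held fixed, this pair isolates the change at this one place, which the earlier compounds could not do, and the larger selenium-bearing group leaves the number within the scatter of the methylsulfanyl compound. No supporting measurement is available to explain this outcome.

The change replaces the selenium and adds the aromatic ring in a single step, so the part played by each stays unresolved; a benzylsulfanyl group, holding sulfur with the same ring, would separate the two. Also open, as far as these compounds go, is whether any group at this place, such as an amine or a longer alkyl chain on the sulfur, would give a step beyond the scatter.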